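The compounds below may be only part of what the source reports. "The series", "measured", "known", "first", "only" and "open" are said of these compounds alone.

Measured compounds:
- Compound 1, `CC(C)c1cccc(C(C)C)c1NC(=O)NS(=O)(=O)N(Cc1ccccc1)Cc1ccccc1`, gives 2200 nM in an assay on liver for inhibition of sterol O-acyltransferase 1 (Rattus norvegicus), using microsomes; on this read-out lower numbers stand for stronger inhibition and higher numbers for weaker inhibition.
- Compound 2, `CC(C)c1cc(C(C)C)c(OS(=O)(=O)NC(=O)Oc2c(C(C)C)cccc2C(C)C)c(C(C)C)c1`, gives 29000 nM in this assay.

Of the two numbers, compound 2 stands highest, which on this read-out means the weaker of the two inhibitors; compound 1 sits well clear of it, beyond the usual scatter. Compound 3, `CC(C)c1cccc(C(C)C)c1OC(=O)NS(=O)(=O)Oc1c(C(C)C)cc(O)cc1C(C)C`, has not yet been measured. It differs from compound 2 in one place: hydroxy in place of isopropyl on an aromatic carbon, the place being meta to two isopropyl groups and para to a large group.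

Going by the values given here, no measured pair shows what this exchange does, so the expectation can rest only on compound 2 itself and on the size of the change. A step from compound 2 to compound 3 of moderate size, toward a higher number and thus weaker inhibition, is expected, a 1.7-fold higher number from compound 2 to compound 3 (0.24 log units; within the scatter), though a step within the scatter cannot be excluded. Compound 3 is therefore estimated at 50000 nM, with a range from 15000 nM to 200000 nM.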

Compound 3, half-maximal inhibitory concentration: > 50000 nM
Compound 3: no number, only a limit; the forecaster's own chance of this, stated with the estimate: 25%; the middle value sits exactly at the limit.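

In this assay compound 3 gives > 50000 nM, and this value is a limit of the assay, not a number. Going by these compounds alone, replacing isopropyl with hydroxy at this place, meta to two isopropyl groups and para to a large group, gives an at least 1.7-fold higher number from compound 2 to compound 3 (0.23 log units; that floor lies within the scatter), which is the first reading of this exchange at this place, and it shows that the exchange brings no move toward a lower number and so no stronger inhibition. Only a floor can be read for the step, and the true size remains unknown, as the result stops at the edge of what the assay reports: the limit of > 50000 nM in this assay, at which 1 of the 3 values shown sits.

From the compounds shown here alone, what remains open is how far past the limit compound 3 really lies, and so whether this exchange moves the number beyond the usual scatter at all. Also open, going by these compounds, is how methoxy, an amine or a short chain such as ethyl would read at this place, and comparing such groups could help separate the effect of losing isopropyl from the effect of adding hydroxy.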